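A few compounds are considered here, and "the series" means these few. Any claim that something is new, unique, unknown or untested is made for them only; others in the source may bear on it.

Three compounds from this set have been examined in a functional assay on HepG2 cells (Homo sapiens) for cytotoxicity, read by MTT assay, with a stated time of 24 h (on this read-out higher numbers stand for weaker inhibition and lower numbers for stronger inhibition), and all three sit at a limit of the assay rather than at a number. Compound 1 `Nc1cccn2cc(Cc3ccc(F)cc3)c(=O)nc12` carries an amino group on its core. In this assay compound 1 gives > 1000000 nM, which is a limit of the assay. Compound 2 `O=c1nc2ccc(Br)cn2cc1Cc1ccccc1` carries a bromo group on a different core. In this assay compound 2 gives > 1000000 nM, again a limit. Compound 3 `O=c1nc2ccccn2cc1Cc1ccc(F)cc1` lacks the amino group of compound 1. In this assay compound 3 gives > 1000000 nM, also a limit.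

Compound 3 and compound 1 differ in a single place: amino in place of hydrogen on an aromatic carbon. The size of the step that the two limits leave unreadable from compound 3 to compound 1 cannot be read, because of the limit of > 1000000 nM in this assay, at which 3 of the 3 values shown sit. How the core of compound 2 differs from the core of compound 3 is not broken down here.

Compound 4 `Nc1cc(Br)cn2cc(Cc3ccccc3)c(=O)nc12` has not yet been measured. It differs from compound 2 by amino in place of hydrogen on an aromatic carbon. Among the measured compounds shown here, this is the same kind of change as that from compound 3 to compound 1, but the surroundings are not identical: in compound 4 the entering group sits meta to a bromo group (1 heavy atom), which has no counterpart in compound 1. The step from compound 2 to compound 4 is expected to be a number no higher from compound 2 to compound 4 (the limit leaves the size open), meaning no readable change. This expectation rests on (the limit of > 1000000 nM in this assay, at which 3 of the 3 values shown sit). For compound 4 the estimated value is 1000000 nM, with a range from 400000 nM to 3000000 nM, and most likely only a limit will again be reported.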

Compound 4, half-maximal inhibitory concentration: > 1000000 nM
Compound 4: no number, only a limit (the forecaster's own chance of this, stated with the estimate: 85%); the middle value sits exactly at the limit.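

Compound 4 adds no readable step: compared with compound 2, the size of the change cannot be read in this assay, because both compounds sit at a limit rather than at a number: the limit of > 1000000 nM in this assay, at which 4 of the 4 values shown sit.

Whether amino in place of hydrogen on an aromatic carbon changes cytotoxicity at all stays open in the compounds shown, and so does any ranking among the four.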